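The compounds below may be only part of what the source reports. "The series", "measured", "known", "first", "only" and "open" are said of these compounds alone.

Compound 1, `c1cncc(-c2ccccc2OCC2=NCCN2)c1`, gives 79.4 nM in a functional assay for activation of Alpha-1B adrenergic receptor (Homo sapiens), read by calcium flux; a lower number here means that less compound is needed, a higher number that more compound is needed for the effect.
Compound 2, `c1ccc(-c2cnccn2)c(OCC2=NCCN2)c1`, gives 631 nM in this assay.
Compound 3, `c1ccc(-c2ccsc2)c(OCC2=NCCN2)c1`, gives 15.9 nM in this assay.

Among these three, compound 2 stands highest in this assay: its nearest neighbour is compound 1, reached by a 7.9-fold higher number from compound 1 to compound 2 (0.90 log units; beyond the scatter), and the furthest is compound 3, reached by a 40-fold lower number from compound 2 to compound 3 (1.60 log units; beyond the scatter). Both steps lie beyond the scatter, so compound 2 is the weakest of the three on these numbers.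

Compound 4, `Cc1ccc(-c2ccccc2OCC2=NCCN2)s1`, has not been measured. It differs from compound 2 in one place: 5-methylthiophen-2-yl in place of pyrazin-2-yl on an aromatic carbon.

Within the data shown here, the steps that bear on this change are those in which a five-membered ring replaces a six-membered one on the same aromatic carbon. From compound 1 to compound 3 the number fell by a 5.0-fold lower number from compound 1 to compound 3 (0.70 log units; beyond the scatter), and from compound 2 to compound 3 by a 40-fold lower number from compound 2 to compound 3 (1.60 log units; beyond the scatter). Among the measured compounds shown here, compound 4 carries a five-membered ring with one sulfur like compound 3, though attached through a different ring position and bearing a methyl, for which no measured step exists. A large drop from compound 2 is therefore expected, estimated as a 25-fold lower number from compound 2 to compound 4 (1.40 log units; beyond the scatter). Compound 4 is expected to give about 25 nM, within a range of 8 nM to 80 nM.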

Compound 4, half-maximal effective concentration: < 100000 nM
Compound 4: a limit, no number; the forecaster's own chance of this, stated with the estimate: 2%; the middle value does not contradict the limit.
By their numbers in this assay, from the lowest: compound 3; then compound 1; then compound 2.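

In this assay compound 4 gives < 100000 nM, which is a limit of the assay and not a number. Among these compounds, no step from compound 1, compound 2 or compound 3 to compound 4 can be read, and what stands in the way is this: the limit of < 100000 nM in this assay, at which 1 of the 4 values shown sits. The compounds shown leave open whether 5-methylthiophen-2-yl in place of pyrazin-2-yl lowers or raises the number.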